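This account rests on a few compounds, and the source may have more. Where it says the series, first, only, none or still open, it means among the compounds named here.

Measured compounds:
Compound 1 `COc1cc(N2C(N)=C(C#N)C(c3ccc(OC)c4ccccc34)C3=C2CC(C)(C)CC3=O)cc(OC)c1OC`: in a functional assay on Ehrlich cells (Mus musculus) for cytotoxicity, tested at 10 ug/mL (a higher number here means a stronger effect of the compound at the concentration tested, a lower number a weaker effect), compound 1 gives 10%.
Compound 2 `COc1ccccc1C1C(C#N)=C(N)N(c2cc(OC)c(OC)c(OC)c2)C2=C1C(=O)CC(C)(C)C2`: in this assay compound 2 gives 30%.
Compound 3 `COc1cc(N2C(N)=C(C#N)C(c3ccc(C)cc3)C3=C2CC(C)(C)CC3=O)cc(OC)c1OC`: in this assay compound 3 gives 30%.

Compound 3 stands level with compound 2 at the digits shown, the two together the highest of the three numbers, while compound 1 lies lower: a number 20 percentage points higher from compound 1 to compound 3 (beyond the scatter). Compound 4 `COc1cc(N2C(N)=C(C#N)C(c3ccc(O)cc3)C3=C2CC(C)(C)CC3=O)cc(OC)c1OC` differs from compound 3 by hydroxy in place of methyl on an aromatic carbon. Among the compounds with values here, no measured step alters this group; the steps that vary the group on the saturated ring carbon are a number 20 percentage points higher from compound 1 to compound 2 (beyond the scatter), a number 20 percentage points higher from compound 1 to compound 3 (beyond the scatter) and no change at the digits printed from compound 2 to compound 3 (within the scatter), modest at most. On that basis compound 4 is expected to stay close to compound 3, with no step beyond the scatter: no change at the digits printed from compound 3 to compound 4 (within the scatter). The estimate for compound 4 in this assay is 30%, with a range from 15% to 50%.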

Compound 4, a percentage reported as activity, at one concentration (the size of the read-out at that concentration, not a potency): 10%
Estimate against measurement, compound 4: 20 percentage points above, and the stated range ends above it.
By their numbers in this assay, from the lowest: compounds 1 and 4 (each within the scatter of the next); then compounds 2 and 3 (each within the scatter of the next).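

In this assay, within the data shown here, the group on this aromatic carbon, para to a large group, proves able to move the read-out: hydroxy in place of methyl gives a number 20 percentage points lower from compound 3 to compound 4 (beyond the scatter) in the first measured change at this position. The 4-hydroxyphenyl group likewise gives a number 20 percentage points lower from compound 2 to compound 4 (beyond the scatter) against 2-methoxyphenyl, but no change at the digits printed from compound 1 to compound 4 (within the scatter) against 4-methoxynaphthalen-1-yl. Nothing available explains why hydroxy lowers the number here. Whether the lower number is specific to hydroxy remains open, as the compounds shown do not tell how an amine or a carboxylic acid on this carbon would compare.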